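A few compounds are considered here, and "the series" means these few. Any claim that something is new, unique, unknown or untested is made for them only; others in the source may bear on it.

In a functional assay on HepG2 cells (Homo sapiens) for inhibition, read by MTT assay, with a stated time of 48 h (a higher number here means a weaker inhibitor, a lower number a stronger inhibitor), compound 1 `CCSc1nnc(-c2cc(OC)c(OC)c(OC)c2)n1-c1ccc(OC)cc1` reports only a limit, > 60000 nM. Compound 2 `COc1ccc(CSc2nnc(-c3cc(OC)c(OC)c(OC)c3)n2-c2ccc(OC)cc2)cc1` gives a number, 41100 nM. Compound 3 `COc1ccc(CSc2nnc(-c3cc(OC)c(OC)c(OC)c3)n2-c2ccc(N(C)C)cc2)cc1` also reports only a limit, > 60000 nM. Compound 3 therefore has no number of its own and stands at the limit of > 60000 nM in this assay, at which 2 of the 3 values shown sit.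

Compound 4 `COc1cc(-c2nnc(SCC(=O)c3ccc4ccccc4c3)n2-c2ccc(N(C)C)cc2)cc(OC)c1OC` keeps the dimethylamino group of compound 3 and differs from it on a saturated chain carbon bound to a sulfur, where (naphthalen-2-yl)carbonyl takes the place of 4-methoxyphenyl: (naphthalen-2-yl)carbonyl in place of 4-methoxyphenyl on a saturated chain carbon bound to a sulfur.

For the measured compounds named here, two measured steps bear on this change. The one at the same carbon is an at least 1.4-fold lower number from compound 1 to compound 2 (0.16 log units; that floor lies within the scatter). The one that installs the dimethylamino group retained in compound 4 is an at least 1.4-fold higher number from compound 2 to compound 3 (0.16 log units; that floor lies within the scatter). Going by the values given here, both are known only as floors set by the limit, so neither gives a full size, and no tested compound carries the entering group.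

Among the compounds with values here, the group at this carbon is the only change that has led to a number, in compound 2 at 41100 nM, so a moderate move towards a lower number is expected. There is also a real chance that compound 4 ends at another limit. The expected step is an at least 3.0-fold lower number from compound 3 to compound 4 (0.47 log units; beyond the scatter). The estimate for compound 4 is 20000 nM, with an expected range of 3000 nM to 60000 nM.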

Compound 4, half-maximal inhibitory concentration: > 60000 nM
Compound 4: a limit, no number; the forecaster's own chance of this, stated with the estimate: 35%; middle value at least 3.0-fold (0.47 log units) from the limit.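

Compound 4 also reports only a limit, > 60000 nM. Compound 3 is likewise known only as a limit, so the step between these two compounds cannot be read. The compounds shown leave open whether any group on the saturated chain carbon bound to a sulfur gives a measurable number alongside the dimethylamino group.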